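This account rests on a few compounds, and the source may have more. Where it says the series, first, only, none or still open, it means among the compounds named here.

In a physicochemical assay for lipophilicity, measured as octanol-water partition (on this read-out higher numbers stand for higher lipophilicity and lower numbers for lower lipophilicity), compound 1 `C/C(=N\NC(=O)COc1cccc2ccccc12)c1ccc(C#N)cc1Br` reads 3.61 and compound 2 `O=C(COc1cccc2ccccc12)N/N=C/c1ccc([N+](=O)[O-])cc1` reads 3.97 which leaves compound 1 the lower of the two, by a gap beyond the usual scatter of repeat measurements. Compound 3 `C/C(=N\NC(=O)COc1cccc2ccccc12)c1ccccc1O` has not been measured yet. It keeps the core of compound 1 and carries 2-hydroxyphenyl in place of 2-bromo-4-cyanophenyl on a carbon with a double bond to nitrogen. Among the compounds with values here, no measured pair isolates a change of this kind, so any forecast in this assay is rough. A small downward step is expected, possibly none beyond the scatter, and the starting point is compound 1 at 3.61 with a wide margin on both sides. The expected change is a number 0.21 log units lower from compound 1 to compound 3 (within the scatter) as estimated here. For compound 3 the estimated value is 3.4 with 2.9 to 3.9 as the expected range.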

Compound 3, partition coefficient: 3.08
Estimate against measurement, compound 3: 0.32 log units above; low and high end bracket the measured number.
By their numbers in this assay, from the lowest: compound 3; then compound 1; then compound 2.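

In this assay, putting 2-hydroxyphenyl in place of 2-bromo-4-cyanophenyl on a carbon with a double bond to nitrogen gives a number 0.53 log units lower from compound 1 to compound 3 (beyond the scatter) and so shows that the read-out responds to this place on the shared core, something compound 2 could not show, since it differs from compound 1 in more than one place. The swap is several changes at once: the bromine and the nitrile leave, the ring stays, and a hydrogen-bond donor enters. Nothing measured here gives a reason for the step or assigns it to any one of these changes.

The compounds shown leave open how much of the step belongs to the bromine, the nitrile or the hydroxyl group. They also leave open where plain phenyl, 2-methoxyphenyl or 2-aminophenyl would fall at this place.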